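A chlorine for a fluorine on the benzimidazol-2-yl group

This account rests on a few compounds, and the source may have more. Where it says the series, first, only, none or still open, it means among the compounds named here.

Compound 2 `CC(C)C(=O)N1CCC(C[C@@H](c2nc3cc(F)ccc3n2C)N2C(=O)CN(c3ccc(Oc4ccccc4)cc3)C2=O)CC1` holds the only number shown: in an assay on cells for antagonist activity at Bile acid receptor (Homo sapiens), read by a luciferase reporter, with a stated time of 24 h (a higher number here means a weaker inhibitor, a lower number a stronger inhibitor), compound 2 gives 0.06 nM. Compound 1 `Cc1ccc2nc([C@H](CC3CCN(C(=O)C(C)C)CC3)N3C(=O)CN(c4ccc(Oc5ccccc5)cc4)C3=O)n(C)c2c1` gives in this assay only a limit, < 0.001 nM (the limit of < 0.001 nM in this assay, at which 1 of the 2 values shown sits). Going by the values given here, the one measured step, an at least 60-fold higher number from compound 1 to compound 2 (1.77 log units; beyond the scatter), swapped both ring substituents at once. Compound 3 `CC(C)C(=O)N1CCC(C[C@@H](c2nc3ccc(Cl)cc3n2C)N2C(=O)CN(c3ccc(Oc4ccccc4)cc3)C2=O)CC1` differs from compound 2 by 6-chloro-1-methyl-1H-benzimidazol-2-yl in place of 5-fluoro-1-methyl-1H-benzimidazol-2-yl on a saturated chain carbon bound to an amide-type nitrogen in a ring and a saturated chain carbon, so that step bears only loosely on it. Compound 3 is expected to move to a lower number by about a 3.0-fold lower number from compound 2 to compound 3 (0.48 log units; beyond the scatter), an estimate of 0.02 nM with a range from 0.003 nM to 0.15 nM.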

Compound 3, half-maximal inhibitory concentration: 0.05 nM
Compound 3: middle estimate off by 2.5-fold (0.40 log units), on the low side; the measured number falls inside the stated range.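

In this assay the exchange of 5-fluoro-1-methyl-1H-benzimidazol-2-yl for 6-chloro-1-methyl-1H-benzimidazol-2-yl gives a 1.2-fold lower number from compound 2 to compound 3 (0.08 log units; within the scatter) and so does not separate the two groups. Chloro in place of methyl on an aromatic carbon, a change in one place only, gives an at least 50-fold higher number from compound 1 to compound 3 (1.69 log units; beyond the scatter) and so shows a large step from that single exchange. The value of compound 1 in this step is only a limit: the limit of < 0.001 nM in this assay, at which 1 of the 3 values shown sits.

From the compounds shown here alone, how large that step really is remains open. So does whether a methoxy group or a nitrile on that aromatic carbon would read like chloro or like methyl.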